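Swapping furan-2-yl for furan-3-yl at the assay limit

This account rests on a few compounds, and the source may have more. Where it says the series, first, only, none or still open, it means among the compounds named here.

Compound 1 `COc1nc(N)nc2c1c(-c1ccoc1)cn2[C@@H]1O[C@H](CO)[C@@H](O)[C@H]1O`: > 20000 nM
Compound 2 `COc1nc(N)nc2c1c(-c1cccs1)cn2[C@@H]1O[C@H](CO)[C@@H](O)[C@H]1O`: > 20000 nM
Compound 3 `Nc1nc2c(c(-c3ccco3)cn2[C@@H]2O[C@H](CO)[C@@H](O)[C@H]2O)c(=O)[nH]1`: > 20000 nM

In a functional assay on HeLa S3 cells (Homo sapiens) for antiproliferative activity, read by XTT assay, with a stated time of 72 h (on this read-out lower numbers stand for stronger inhibition and higher numbers for weaker inhibition), compound 3 gives > 20000 nM, which is a limit of the assay and not a number. It has no company at any measured potency, and the whole picture so far is the limit of > 20000 nM in this assay, at which 3 of the 3 values shown sit.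

Compound 4 `Nc1nc2c(c(-c3ccoc3)cn2[C@@H]2O[C@H](CO)[C@@H](O)[C@H]2O)c(=O)[nH]1` has the same atoms as compound 3, joined differently, and the change sits on a single aromatic carbon: furan-3-yl in place of furan-2-yl on an aromatic carbon.

Going by the values given here, only one measured step bears on this change, and it does so indirectly: a step that the two limits leave unreadable from compound 1 to compound 2, with thiophen-2-yl in place of furan-3-yl on an aromatic carbon. Its size cannot be read, so it offers no measure of what such a swap can do. Compound 1, which carries the entering furan-3-yl group on a different core, stops at the limit > 20000 nM. Among the compounds with values here, no measured step therefore points to a gain or a loss in this assay, and compound 4 is expected to stay at or near the limit, with no change beyond the usual scatter. The expected change is a step that the limit leaves unreadable from compound 3 to compound 4. For compound 4 the estimated value is 25000 nM, with an expected range from 10000 nM to 50000 nM.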

Compound 4, half-maximal inhibitory concentration: 10700 nM
The estimate for compound 4 lay 2.3-fold (0.37 log units) above the measured number, and the stated range covers the measured number.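

In this assay, moving the point of attachment on the furan ring gives an at least 1.8-fold lower number from compound 3 to compound 4 (0.27 log units; that floor lies within the scatter). The printed floor of this step lies within the usual scatter, so the step alone does not establish a real gain, although the true difference could be larger. What is new is that this position on the shared core can carry a group that gives a measured number instead of a limit, and compound 4 is the only compound shown to do so, while the others remain at the limit: the limit of > 20000 nM in this assay, at which 3 of the 4 values shown sit.

Furan-3-yl does not yield a measured number on every core, as compound 1 carries the same group and gives > 20000 nM, which is a limit of the assay and not a number. As far as these compounds go, the real size of the step from furan-2-yl to furan-3-yl remains open, as does how this position on the core of compound 4 would respond to a phenyl ring, an amine or a longer chain.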